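The source may hold more compounds than are shown below. What is called first, only, known or untested is meant among the compounds shown, and "the series" means these compounds.

Measured in an assay on Sf9 cells for inhibition of protein deacetylase HDAC6 (Homo sapiens), read by fluorescence, with a stated time of 40 min, tested at 100 nM; a higher number here means more inhibition at the concentration tested (going by the name of the read-out), a lower number less inhibition:
- compound 1 `Cc1ccc(-c2nc(CNc3ccc(C(=O)NO)cc3)n(-c3ccccc3)n2)cc1`: 62.2%
- compound 2 `COc1ccc(-c2nc(CNc3ccc(C(=O)NO)cc3)n(-c3ccccc3)n2)cc1`: 77.6%
- compound 3 `O=C(NO)c1ccc(NCc2nc(-c3ccc(C(F)(F)F)cc3)nn2-c2ccccc2)cc1`: 41.6%

Compound 3 stands lowest of the three numbers, and both steps into it lie beyond the scatter: a number 20.6 percentage points lower from compound 1 to compound 3 (beyond the scatter) and a number 36 percentage points lower from compound 2 to compound 3 (beyond the scatter). Among the two higher compounds, a number 15.4 percentage points higher from compound 1 to compound 2 (beyond the scatter).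

The next compound is compound 4 `O=C(NO)c1ccc(NCc2nc(-c3ccccc3Cl)nn2-c2ccccc2)cc1`, which differs from compound 3 in one place: 2-chlorophenyl in place of 4-(trifluoromethyl)phenyl on an aromatic carbon. All three measured steps alter only the group carried on that phenyl ring, and in them the trifluoromethyl-bearing ring gives the lowest number, with methyl and methoxy each higher. None of them exchanges the whole ring for 2-chlorophenyl, so the measured steps bear on the change only indirectly. Given that the measured steps away from the trifluoromethyl ring were all upward, a modest upward step is expected for compound 4, a number 10.4 percentage points higher from compound 3 to compound 4 (beyond the scatter), though the direction is not well supported. In this assay compound 4 is expected to give about 52%, within 35% to 70%.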

Compound 4, a percentage reported as inhibition, at one concentration (the size of the read-out at that concentration, not a potency): 75%
Compound 4: the middle estimate sits 23 percentage points below what was measured; measured number above the stated range.
By their numbers in this assay, from the lowest: compound 3; then compound 1; then compounds 4 and 2 (each within the scatter of the next).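

In this assay, the aromatic carbon between two ring nitrogen atoms carries 2-chlorophenyl as well as the para-free comparison allows: exchanging 4-(trifluoromethyl)phenyl for it gives a number 33.4 percentage points higher from compound 3 to compound 4 (beyond the scatter).

Against 4-methylphenyl the same exchange gives a number 12.8 percentage points higher from compound 1 to compound 4 (beyond the scatter), whereas against 4-methoxyphenyl it gives a number 2.6 percentage points lower from compound 2 to compound 4 (within the scatter), so these two rings cannot be ordered here. Nothing at hand accounts for these differences.

Going by these compounds, compound 4 differs from the others in both the substituent and its place on the ring, so the share of each in these steps stays open, and 4-chlorophenyl or 2-methoxyphenyl would separate them. Also open, on these data alone, is how a ring bearing a carboxylic acid or an amine would read at this carbon.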